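Working notes: from compound 3 to compound 4

The source may report more compounds than this note shows. Statements on the series, on what has been measured and on what is new or still open speak of the compounds shown alone.

Measured in a functional assay on HCT-116 cells (Homo sapiens) for antiproliferative activity, read by sulforhodamine B assay, with a stated time of 72 h (a lower number here means a stronger inhibitor, a higher number a weaker inhibitor), each value a limit of the assay and not a number:
compound 1 `Cn1cc(-c2ccc(=O)n(CCOc3ccnc4cc(OCCCCC(=O)NO)ccc34)n2)cn1`: > 10000 nM
compound 2 `Cn1cc(-c2ccc(=O)n(CCOc3ccnc4cc(OCCCCCS)ccc34)n2)cn1`: > 10000 nM
compound 3 `CC(=O)CCCCCOc1ccc2c(OCCn3nc(-c4cnn(C)c4)ccc3=O)ccnc2c1`: > 10000 nM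

Compound 3 has no number, only the limit > 10000 nM. The whole set sits at one ceiling, (the limit of > 10000 nM in this assay, at which 3 of the 3 values shown sit), so compound 3 cannot be ranked against the other two.

Compound 4 `Cn1cc(-c2ccc(=O)n(CCOc3ccnc4cc(C(=O)Nc5ccccc5N)ccc34)n2)cn1` is not yet measured. It carries (2-aminophenyl)carbamoyl in place of the (5-acetylpentyl)oxy of compound 3, on an aromatic carbon: (2-aminophenyl)carbamoyl in place of (5-acetylpentyl)oxy on an aromatic carbon. This replaces the whole chain and adds an aromatic ring of carbon only.

Going by the values given here, three measured steps bear on it, as each swaps a group on the saturated chain: a step that the two limits leave unreadable from compound 1 to compound 2, a step that the two limits leave unreadable from compound 1 to compound 3 and a step that the two limits leave unreadable from compound 2 to compound 3. None of them has a readable size, and none replaces the chain outright, so no size or direction carries over to this assay. The expectation is therefore no step beyond the scatter, and compound 4 may well return a limit too.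

The estimate rests on compound 3, whose > 10000 nM is a limit. The expected step is a number no higher from compound 3 to compound 4 (the limit leaves the size open). Compound 4 is estimated at 10000 nM, with an expected range of 2500 nM to 30000 nM.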

Compound 4, half-maximal inhibitory concentration: > 10000 nM
Compound 4: no number, only a limit; the forecaster's own chance of this, stated with the estimate: 70%; the middle value lies on the limit itself.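

In this assay compound 4 gives only a limit, as do compound 1, compound 2 and compound 3, so no step among these compounds can be read: the limit of > 10000 nM in this assay, at which 4 of the 4 values shown sit.

The compounds shown leave open how these four rank against one another, and whether (2-aminophenyl)carbamoyl or any of the chains changes the activity at all.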